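A methyl added to compound 1 at the assay limit

A few compounds are considered here, and "the series" means these few. Any claim that something is new, unique, unknown or untested is made for them only; others in the source may bear on it.

In a functional assay on SNB-19 cells (Homo sapiens) for inhibition, read by MTT assay, with a stated time of 7 days (on this read-out higher numbers stand for weaker inhibition of growth and lower numbers for stronger inhibition of growth), compound 1 (`NC(=O)c1ncn2c(=O)n(Cc3ccccc3)nnc12`) gives > 50000 nM as a limit and not a number. Compound 2 (`Cc1cc(Cn2nnc3c(C(N)=O)ncn3c2=O)on1`) gives > 50000 nM as a limit too. The step that the two limits leave unreadable from compound 1 to compound 2 therefore has no readable size, and the data hold only the limit of > 50000 nM in this assay, at which 2 of the 2 values shown sit, for now. Compound 3 (`C[C@H](c1ccccc1)n1nnc2c(C(N)=O)ncn2c1=O`) carries methyl in place of hydrogen on a saturated chain carbon bound to an aromatic carbon and an aromatic nitrogen. Within the data shown here, no measured step covers this change. The expected step of a number no higher from compound 1 to compound 3 (the limit leaves the size open) stays within the scatter. Compound 3 is estimated at 50000 nM with a range from 25000 nM to 100000 nM and is expected to appear as a limit again.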

Compound 3, concentration for 50% growth inhibition: 32700 nM
Beside the measured number, compound 3's estimate is 1.5-fold (0.18 log units) above it; the measured number falls inside the stated range.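

In this assay, methyl in place of hydrogen on a saturated chain carbon bound to an aromatic carbon and an aromatic nitrogen gives an at least 1.5-fold lower number from compound 1 to compound 3 (0.18 log units; that floor lies within the scatter). That floor is all the data fix, so the change cannot be said to shift growth inhibition by more than the usual scatter, though the true step may be larger. Compound 3 is the only compound shown that gives a number and not a limit: the limit of > 50000 nM in this assay, at which 2 of the 3 values shown sit.

The compounds shown leave open what an ethyl group, a longer chain or a hydroxyl group on this carbon would give. From the compounds shown here alone, the opposite spatial arrangement of the methyl also remains open.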